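The source may report more compounds than this note shows. Statements on the series, on what has been measured and on what is new or still open speak of the compounds shown alone.

Series notes, measured in an ADME assay on HepG2 cells (Homo sapiens) for cytotoxicity, with a stated time of 72 h; on this read-out higher numbers stand for an effect only at larger amounts of compound and lower numbers for an effect already at smaller amounts:

- Compound 1 `Cc1cc(NC(=O)Nc2cccc([N+](=O)[O-])c2)c2ccccc2n1`: > 25000 nM (a limit, not a number)
- Compound 2 `Cc1ccc(NC(=O)Nc2cc(C)nc3ccccc23)cc1`: > 25000 nM (a limit, not a number)
- Compound 3 `Cc1cc(NC(=O)Nc2ccc(F)c(F)c2)c2ccccc2n1`: 21000 nM

For the measured compounds named here, compound 3 at 21000 nM holds the only true number in the set. The other two results are limits of the assay, and the record for them reads: the limit of > 25000 nM in this assay, at which 2 of the 3 values shown sit. Going by the values given here, no step between measured compounds differing in one place is available, so no single change has a measured size.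

Next is compound 4 `Cc1cc(NC(=O)Nc2cccc(F)c2)c2ccccc2n1`, not yet measured in this assay. The structural change is hydrogen in place of fluoro on an aromatic carbon. Among the compounds with values here, the expectation for this change is no step beyond the scatter, resting on compound 3 at 21000 nM, the one number available. Expected on that basis is a 1.1-fold higher number from compound 3 to compound 4 (0.06 log units; within the scatter), with no firm direction. A result reported only as a limit of the assay would also fit this expectation. For compound 4 the estimated value is 24000 nM, with an expected range of 14000 nM to 42000 nM.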

Compound 4, half-maximal effective concentration: > 25000 nM
Compound 4 was reported as a limit; the forecaster's own chance of this, stated with the estimate: 50%; middle value at least 1.0-fold (0.01 log units) away from the limit.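

In this assay compound 4 gives > 25000 nM, a limit and not a number. Hydrogen in place of fluoro on an aromatic carbon, ortho to a fluoro group and para to a large group, is the first single change in the series with any bound on its size, and that bound is only a floor: an at least 1.1-fold higher number from compound 3 to compound 4 (0.07 log units; that floor lies within the scatter). The steps linking compound 4 to compound 1 and to compound 2 cannot be read, as both ends of each are limits, and the series now gathers at one reading: the limit of > 25000 nM in this assay, at which 3 of the 4 values shown sit.

The upper end of the step remains unbounded, so the compounds shown cannot separate a change within the scatter from a larger one at this position. Also open, from the compounds shown here alone, is how an amine or a carboxylic acid on this ring in place of fluoro would read, and whether any change to the shared core would turn the limits into true numbers.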